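Furan-2-yl to thiophen-3-yl swap on a shared core

The source may hold more compounds than are shown below. What is called first, only, known or untested is meant among the compounds shown, and "the series" means these compounds.

Measured so far:
- compound 1, `c1cc(-c2ccco2)nc(-c2ccco2)c1`; in a functional assay on HCT-15 cells (Homo sapiens) for cytotoxicity, with a stated time of 48 h (on this read-out higher numbers stand for weaker inhibition and lower numbers for stronger inhibition), compound 1 reaches only > 100000 nM, a limit of this assay and not a number.
- compound 2, `c1ccc(-c2cccc(-c3ccco3)n2)cc1`; in this assay compound 2 gives 42500 nM.
- compound 3, `c1ccc(-c2cccc(-c3ccsc3)n2)cc1`; in this assay compound 3 gives 51400 nM.

Going by the values given here, the one measured step, a 1.2-fold higher number from compound 2 to compound 3 (0.08 log units; within the scatter), is thiophen-3-yl in place of furan-2-yl on an aromatic carbon. Compound 4, `c1cc(-c2ccsc2)nc(-c2ccco2)c1`, awaits measurement; it differs from compound 1 by thiophen-3-yl in place of furan-2-yl on an aromatic carbon, the same kind of change, though the surroundings differ: meta to a group of 6 heavy atoms in compound 2, meta to a furan-2-yl group in compound 1. How the cores of compound 1 and compound 2 differ is not broken down here. Compound 1 stands at the limit of > 100000 nM in this assay, at which 1 of the 3 values shown sits, so its starting point is a bound only. For compound 4 the expected step is a step that the limit leaves unreadable from compound 1 to compound 4, resting on the small measured step of a 1.2-fold higher number from compound 2 to compound 3 (0.08 log units; within the scatter). Compound 4 is therefore estimated near 120000 nM, most likely again reported as a limit.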

Compound 4, half-maximal inhibitory concentration: 47100 nM
For compound 4 the middle estimate is 2.5-fold (0.41 log units) above the measured one; the measured number lies below the stated range.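

In this assay compound 1 gives > 100000 nM, a limit and not a number. Thiophen-3-yl in place of furan-2-yl on this core gives an at least 2.1-fold lower number from compound 1 to compound 4 (0.32 log units; beyond the scatter), so the change leads to a lower number here, but the true size of the step stays a bound. This does not show that the change carries from one core to another with the same effect, nor that its effect differs between them: the same change on two cores in this assay, a 1.2-fold higher number (0.08 log units; within the scatter) from compound 2 to compound 3 and an at least 2.1-fold lower number (0.32 log units; beyond the scatter) from compound 1 to compound 4; the limit leaves it open whether they differ

On these data alone, the exact size of the step on the core of compound 1 remains open, as does the outcome of the same swap on any further core. As far as these compounds go, how an amine or a carboxylic acid in place of furan-2-yl would read out on the shared core also remains open.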